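Swapping iodo for ethoxy on a shared core

This account rests on a few compounds, and the source may have more. Where it says the series, first, only, none or still open, it means among the compounds named here.

For the measured compounds named here, in a functional assay on MKN-28 cells (Homo sapiens) for cytotoxicity, read by MTT assay (a higher number here means a weaker inhibitor, a lower number a stronger inhibitor), compound 2 `C=C1C(=O)[C@]23C[C@@]1(I)CC[C@H]2[C@@]12C=CC(=O)[C@](C)(C(=O)O1)[C@H]2[C@@H]3C(=O)OCc1ccccc1` gives 3000 nM, the lower of the two numbers so far. Its only measured relative, compound 1 `C=C1C(=O)[C@]23C[C@@]1(F)CC[C@H]2[C@@]12C=CC(=O)[C@](C)(C(=O)O1)[C@H]2[C@@H]3C(=O)OCc1ccccc1`, gives 9800 nM and carries fluoro where compound 2 carries iodo. Compound 3 `C=C1C(=O)[C@]23C[C@@]1(OCC)CC[C@H]2[C@@]12C=CC(=O)[C@](C)(C(=O)O1)[C@H]2[C@@H]3C(=O)OCc1ccccc1` keeps the same core but has ethoxy in place of iodo on a saturated ring carbon. Going by the values given here, one measured step bears on this change: a 3.3-fold lower number from compound 1 to compound 2 (0.51 log units; beyond the scatter). That step is modest and swaps one halogen for another, so it is only a rough guide to what ethoxy will do. With compound 2 at 3000 nM, the lower end so far, a modest move to a higher number in this assay seems likelier than a further drop. The expected change is a 2.2-fold higher number from compound 2 to compound 3 (0.34 log units; beyond the scatter). For compound 3 the estimated value is 6500 nM, with an expected range from 2000 nM to 20000 nM.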

Compound 3, half-maximal inhibitory concentration: 16500 nM
Compound 3: the middle estimate sits 2.5-fold (0.40 log units) below what was measured; measured number inside the range.
By their numbers in this assay, from the lowest: compound 2; then compounds 1 and 3 (each within the scatter of the next).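

In this assay, putting ethoxy in place of iodo on this saturated ring carbon gives a 5.5-fold higher number from compound 2 to compound 3 (0.74 log units; beyond the scatter), so the lower number seen with iodo does not carry over to this oxygen-linked group. Setting ethoxy against fluoro gives a 1.7-fold higher number from compound 1 to compound 3 (0.23 log units; within the scatter), which means that these two groups cannot be told apart in this assay, even though they are very different substituents. Of the three groups seen at this position, iodo alone stands apart, with a number beyond the scatter of both others.

Nothing shown here explains why iodo behaves differently from the other two groups. Also open, as far as these compounds go, is whether chloro or bromo would fall near iodo, and how an amine, a hydroxyl group or a longer chain such as butoxy would read at this carbon.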